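Aryl thiourea variation in the electroshock series

The compounds below may be only part of what the source reports. "The series", "measured", "known", "first", "only" and "open" are said of these compounds alone.

Measured compounds:
compound 1 `COc1cc2c(cc1OC)C(=O)C(CC1CCN(C(=S)Nc3ccccc3C)CC1)C2`: 100 mg/kg
compound 2 `COc1cc2c(cc1OC)C(=O)C(CC1CCN(C(=S)Nc3cccc(C)c3)CC1)C2`: 300 mg/kg
compound 3 `COc1cc2c(cc1OC)C(=O)C(CC1CCN(C(=S)Nc3ccc(C)cc3)CC1)C2`: 30 mg/kg

In a functional assay on the whole organism (strain Swiss albino) with Mus musculus as the target, in the maximal electroshock model, with a stated time of 0.5 h (on this read-out higher numbers stand for an effect only at larger amounts of compound and lower numbers for an effect already at smaller amounts), compound 3 gives 30 mg/kg, the lowest of the three numbers. The separation is beyond the scatter in both directions: a 3.3-fold lower number from compound 1 to compound 3 (0.52 log units; beyond the scatter) and a 10-fold lower number from compound 2 to compound 3 (1.00 log units; beyond the scatter). The other exchange among the methylphenyl groups, a 3.0-fold higher number from compound 1 to compound 2 (0.48 log units; beyond the scatter), is also beyond the scatter, so the three methyl positions give three distinguishable numbers.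

Compound 4 `COc1cc2c(cc1OC)C(=O)C(CC1CCN(C(=S)Nc3ccccc3[N+](=O)[O-])CC1)C2` differs from compound 3 by 2-nitrophenyl in place of 4-methylphenyl on an amide-type nitrogen. Among the compounds with values here, only one measured step bears on it directly: a 3.3-fold lower number from compound 1 to compound 3 (0.52 log units; beyond the scatter) compares 2-methylphenyl with 4-methylphenyl, and compound 4 returns to a 2-substituted phenyl, so reversing that step is the nearest guide. Within the data shown here, no measured pair exchanges methyl for nitro, so the size of that part of the change is unknown. The expectation for compound 4 is a step back up, a 3.3-fold higher number from compound 3 to compound 4 (0.52 log units; beyond the scatter), toward the level of compound 1.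

Compound 4 is therefore estimated at 100 mg/kg, with a range of 30 mg/kg to 300 mg/kg.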

Compound 4, minimum effective dose: 100 mg/kg
Estimate against measurement, compound 4: no gap at the digits printed; measured number inside the range.
By their numbers in this assay, from the lowest: compound 3; then compounds 1 and 4 (each within the scatter of the next); then compound 2.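

In this assay, the exchange of the substituent itself, rather than its place on the phenyl ring, gives no change at the digits printed from compound 1 to compound 4 (within the scatter), so 2-nitrophenyl and 2-methylphenyl on the amide-type nitrogen cannot be told apart in this read-out, though this rests on a single pair. Compound 4 is also separated from the two remaining methylphenyl compounds, with a 3.3-fold higher number from compound 3 to compound 4 (0.52 log units; beyond the scatter) and a 3.0-fold lower number from compound 2 to compound 4 (0.48 log units; beyond the scatter), which leaves compound 3 with the lowest number of the four, its steps to all others being beyond the scatter. Nothing available gives a reason for these numbers.

As far as these compounds go, whether nitro and methyl also match as 4-nitrophenyl against compound 3 or as 3-nitrophenyl against compound 2 remains open. So does the outcome for a 2-aminophenyl or 2-carboxyphenyl group at this nitrogen.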